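Replacing an Ethyl Group by Acetyl on a Ring Nitrogen

The compounds below may be only part of what the source reports. "The series", "measured", "known", "first", "only" and "open" are said of these compounds alone.

Measured so far:
- compound 1, `CC(C)(C)c1cc(/C=C2\CCNC2=O)cc(C(C)(C)C)c1O`: 36%
- compound 2, `CN1CC/C(=C\c2cc(C(C)(C)C)c(O)c(C(C)(C)C)c2)C1=O`: 50%
- compound 3, `CCN1CC/C(=C\c2cc(C(C)(C)C)c(O)c(C(C)(C)C)c2)C1=O`: 30%

All three compounds share one core and differ only in what sits on the amide-type nitrogen in a ring. In a functional assay on the whole organism for inhibition, with Rattus norvegicus as the target, at a dose of 1 mg/kg (a lower number here means a weaker effect, a higher number a stronger effect of the compound at the dose given), compound 3 stands lowest of the three numbers; its nearest neighbour is compound 1, a step that lies within the scatter, while the gap to compound 2 lies beyond it, as a number 20 percentage points lower from compound 2 to compound 3 (beyond the scatter) shows.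

Compound 4, `CC(=O)N1CC/C(=C\c2cc(C(C)(C)C)c(O)c(C(C)(C)C)c2)C1=O`, has not been measured. It differs from compound 3 in one place: acetyl in place of ethyl on an amide-type nitrogen in a ring.

Among the measured compounds shown here, no measured step introduces an acetyl group, so none bears directly on this change. The steps that come closest concern the same nitrogen: a number 14 percentage points higher from compound 1 to compound 2 (beyond the scatter) and a number 6 percentage points lower from compound 1 to compound 3 (within the scatter). They show that changing this substituent moves the number only modestly, in either direction. A step of similar size, or none beyond the scatter, is therefore expected, as a number 5 percentage points higher from compound 3 to compound 4 (within the scatter).

For compound 4 in this assay the expected value is 35%, estimated to lie between 15% and 58%.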

Compound 4, a percentage reported as inhibition, in the whole organism at one dose (the size of the read-out at that dose, not a potency): 53%
Compound 4: the middle estimate sits 18 percentage points below what was measured; the measured number falls inside the stated range.
By their numbers in this assay, from the lowest: compounds 3 and 1 (each within the scatter of the next); then compounds 2 and 4 (each within the scatter of the next).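

In this assay, the step from ethyl to acetyl gives a number 23 percentage points higher from compound 3 to compound 4 (beyond the scatter), and the step from the amide hydrogen to acetyl gives a number 17 percentage points higher from compound 1 to compound 4 (beyond the scatter), so this position can lift the number well clear of what the ethyl group and the bare nitrogen give. Against methyl, acetyl gives a number 3 percentage points higher from compound 2 to compound 4 (within the scatter), which means that two groups differing in heavy atoms and in the presence of a hydrogen-bond acceptor cannot be told apart here, and that the number does not simply fall as the group on the nitrogen grows, since acetyl is larger than ethyl yet reads higher. Nothing measured on these compounds explains why acetyl and ethyl part ways at this nitrogen.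

The compounds shown leave open whether the carbonyl of the acetyl group is what counts, which a propionyl group, a methylsulfonyl group or a longer chain such as propyl on the same nitrogen would help to test. On these data alone, each number also comes from a single dose, so it remains open whether compound 2 and compound 4 would still read alike at other doses.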